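Nitro to fluoro on the cinnamoyl aryl ring

This account rests on a few compounds, and the source may have more. Where it says the series, first, only, none or still open, it means among the compounds named here.

Three hydrazides sharing one core have been tested in an ADME assay on cells (Macrophage) for cytotoxicity, read by MTT assay, with a stated time of 24 h; a lower number here means that less compound is tolerated, a higher number that more compound is tolerated. Compound 2 `O=C(/C=C/c1cccc([N+](=O)[O-])c1)NNC(=O)c1ccc2c(c1)OCCO2` gives 323000 nM, compound 1 `O=C(/C=C/c1ccccc1Br)NNC(=O)c1ccc2c(c1)OCCO2` gives 315000 nM, and compound 3 `Cc1cccc(/C=C/C(=O)NNC(=O)c2ccc3c(c2)OCCO3)c1` gives 281000 nM; compound 2 stands at the top of these numbers, yet every gap is within the scatter, as the steps of a 1.0-fold higher number from compound 1 to compound 2 (0.01 log units; within the scatter), a 1.1-fold lower number from compound 1 to compound 3 (0.05 log units; within the scatter) and a 1.1-fold lower number from compound 2 to compound 3 (0.06 log units; within the scatter) show. Compound 4 `O=C(/C=C/c1cccc(F)c1)NNC(=O)c1ccc2c(c1)OCCO2` differs from compound 2 by fluoro in place of nitro on an aromatic carbon. Within the data shown here, the one step bearing on this is the change at the same aromatic carbon, a 1.1-fold lower number from compound 2 to compound 3 (0.06 log units; within the scatter), which stayed within the scatter, so no step beyond the scatter is expected here either. Compound 4 is therefore estimated at 305000 nM, ranging from 200000 nM to 460000 nM, an expected step of a 1.1-fold lower number from compound 2 to compound 4 (0.02 log units; within the scatter).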

Compound 4, half-maximal cytotoxic concentration: 221000 nM
Beside the measured number, compound 4's estimate is 1.4-fold (0.14 log units) above it; low and high end bracket the measured number.
By their numbers in this assay, from the lowest: compounds 4, 3, 1 and 2 (each within the scatter of the next).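

Fluoro in place of nitro at this aromatic carbon comes to a 1.5-fold lower number from compound 2 to compound 4 (0.16 log units; within the scatter) and fluoro in place of methyl comes to a 1.3-fold lower number from compound 3 to compound 4 (0.10 log units; within the scatter) in this assay here. The change from 2-bromophenyl to 3-fluorophenyl likewise comes to a 1.4-fold lower number from compound 1 to compound 4 (0.15 log units; within the scatter) at this stage, so adding fluoro to the series still produces no step beyond the scatter. No measurement at hand offers an explanation for these numbers. As far as these compounds go, whether an amine, a carboxylic acid or a longer chain at this aromatic carbon would produce a step beyond the scatter remains open.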